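This account rests on a few compounds, and the source may have more. Where it says the series, first, only, none or still open, it means among the compounds named here.

Compound 1 `CC(C)c1ccc(-c2oc3ccc(C(=O)O)cc3c(=O)c2O)cc1` gives 24% in a functional assay on the whole organism (stomach) for inhibition, with Rattus norvegicus as the target, at a dose of 80 mg/kg; a lower number here means less inhibition, a higher number more inhibition at the dose given (going by the name of the read-out); compound 2 `O=C(O)c1ccc2oc(-c3ccc(Cl)cc3)c(O)c(=O)c2c1` gives -19%.

Compound 2 stands lowest of the two numbers. Going by the values given here, the only measured step, a number 43 percentage points lower from compound 1 to compound 2 (beyond the scatter), changed the group at the same place on the same ring, but did not involve carboxy. Compound 3 `O=C(O)c1ccc(-c2oc3ccc(C(=O)O)cc3c(=O)c2O)cc1` differs from compound 2 by carboxy in place of chloro on an aromatic carbon. Among the compounds with values here, with no step in the data covering carboxy, the one measured step is only a loose guide. The expected step is a number 24 percentage points higher from compound 2 to compound 3 (beyond the scatter), a modest rise carrying wide uncertainty. Compound 3 is therefore estimated at 5% in this assay, with a range from -25% to 35%.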

Compound 3, a percentage reported as inhibition, in the whole organism at one dose (the size of the read-out at that dose, not a potency): 23%
Beside the measured number, compound 3's estimate is 18 percentage points below it; the measured number falls inside the stated range.
By their numbers in this assay, from the lowest: compound 2; then compounds 3 and 1 (each within the scatter of the next).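

On the aromatic carbon para to a large group, carboxy separates clearly from chloro in this assay, with a number 42 percentage points higher from compound 2 to compound 3 (beyond the scatter). Carboxy and isopropyl cannot be told apart here, with a number 1 percentage points lower from compound 1 to compound 3 (within the scatter), so among these three groups chloro alone stands apart, beyond the scatter from both others. Nothing at hand explains why this position responds in this way. From the compounds shown here alone, it remains open whether an amine, a methoxy group or a longer alkyl chain at this place would track chloro or the other two groups.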